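A few compounds are considered here, and "the series" means these few. Any claim that something is new, unique, unknown or untested is made for them only; others in the source may bear on it.

Compound 1 `CC(C)c1nccc2nn(-c3ccccc3)cc12` gives > 100000 nM in a functional assay on K562 cells (Homo sapiens) for inhibition, read by fluorescence, with a stated time of 72 h (a higher number here means a weaker inhibitor of growth, a lower number a stronger inhibitor of growth), which is a limit of the assay rather than a number.
Compound 2 `CCCCCc1cc2nn(-c3ccccc3)cc2cn1` gives 2100 nM in this assay.
Compound 3 `CCCCc1cc2nn(-c3ccccc3)cc2cn1` gives 6700 nM in this assay.

Of the two actual numbers, compound 2 has the lowest; its nearest neighbour is compound 3, reached by a 3.2-fold higher number from compound 2 to compound 3 (0.50 log units; beyond the scatter), with hydrogen in place of methyl on a saturated chain carbon, four bonds along the chain from an aromatic carbon. Compound 4 `CCCCCc1cc2nn(-c3ccccc3)cc2c(C)n1` has not yet been measured. It differs from compound 2 by methyl in place of hydrogen on an aromatic carbon. Within the data shown here, the only measured step, a 3.2-fold higher number from compound 2 to compound 3 (0.50 log units; beyond the scatter), alters the chain and does not bear directly on a change at the aromatic core. Compound 4 is therefore expected to give about 2500 nM in this assay. The expected range for compound 4 runs from 700 nM to 9000 nM. That amounts to an expected step of a 1.2-fold higher number from compound 2 to compound 4 (0.08 log units; within the scatter), not beyond the scatter.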

Compound 4, concentration for 50% growth inhibition: 6900 nM
For compound 4 the middle estimate is 2.8-fold (0.44 log units) below the measured one; the measured number falls inside the stated range.
By their numbers in this assay, from the lowest: compound 2; then compounds 3 and 4 (each within the scatter of the next). At a limit, above all of these: compound 1.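

Methyl in place of hydrogen on the aromatic carbon next to the ring nitrogen brings a 3.3-fold higher number from compound 2 to compound 4 (0.52 log units; beyond the scatter) in this assay. Among these compounds, the only earlier one-place step lay in the chain, so this is the first sign that the core also matters: a single added heavy atom at this position gives a weaker inhibitor of growth. No measurement shown here explains this step.

As far as these compounds go, whether an amine or a methoxy group on this same carbon would also weaken inhibition stays open. So does whether methyl has the same effect alongside a longer chain.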